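Benzyl ether variation: chlorothiophene in place of chlorophenyl

A few compounds are considered here, and "the series" means these few. Any claim that something is new, unique, unknown or untested is made for them only; others in the source may bear on it.

Measured so far:
- compound 1 `Cc1nc2ccc(-n3ccc(OCc4ccc(F)cc4)cc3=O)cc2n1C`: 65 nM
- compound 2 `Cn1c(C2CC2)nc2ccc(-n3ccc(OCc4cccc(Cl)c4)cc3=O)cc21`: 72 nM

Both compounds were run in an assay on CHO cells for displacement of a labelled ligand from melanin-concentrating hormone receptor 1 (Rattus norvegicus), read by scintillation counting, with a stated time of 1 h; on this read-out lower numbers stand for stronger inhibition and higher numbers for weaker inhibition. Compound 1 gives 65 nM and compound 2 gives 72 nM. On these two numbers compound 2 sits alongside compound 1; the gap between them is within the scatter, so nothing separates the two ether variants on this read-out.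

The next compound, compound 3 `Cn1c(C2CC2)nc2ccc(-n3ccc(OCc4csc(Cl)c4)cc3=O)cc21`, keeps the core of compound 2 and alters only the benzyl ether: 5-chlorothiophen-3-yl in place of 3-chlorophenyl on a saturated chain carbon bound to an oxygen on an aromatic ring. Within the data shown here, no measured pair shows this change, so its effect has to be guessed from the two values in hand. Compound 1 and compound 2 differ at the same end of the molecule and still land within the scatter of each other in this assay, which suggests that this region tolerates small changes. The step from compound 2 to compound 3 is therefore expected to be small, in either direction or not beyond the scatter, as a 1.3-fold higher number from compound 2 to compound 3 (0.10 log units; within the scatter). Compound 3 is estimated at 90 nM in this assay, with a range from 35 nM to 250 nM.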

Compound 3, half-maximal inhibitory concentration: 9.3 nM
Compound 3: middle estimate off by 9.7-fold (0.99 log units), on the high side, and the stated range ends above it.
By their numbers in this assay, from the lowest: compound 3; then compounds 1 and 2 (each within the scatter of the next).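

In this assay, replacing 3-chlorophenyl with 5-chlorothiophen-3-yl on a saturated chain carbon bound to an oxygen on an aromatic ring gives a 7.7-fold lower number from compound 2 to compound 3 (0.89 log units; beyond the scatter) on an unchanged core, so this position responds to the identity of the aromatic ring. Among these compounds, compound 1 and compound 2 differ in more than one place, so their close values could not isolate this position, and this pair gives the first reading of a change made in one place only. The chlorine stays while a six-membered aromatic ring of carbon only gives way to a five-membered aromatic ring with 1 hetero atom, but the values in hand offer no measured explanation for the lower number.

As far as these compounds go, it remains open whether the thiophene ring alone accounts for the step, or whether it depends on the chlorine, as a thiophene without chlorine or one carrying a methyl group in its place would show. Also open, from the compounds shown here alone, are how a pyridine ring would read at this position and whether the same exchange would give a similar step on the core of compound 1.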